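Adding a methoxy group to two different quinazoline-like amines

The source may report more compounds than this note shows. Statements on the series, on what has been measured and on what is new or still open speak of the compounds shown alone.

Compound 1 `CCCCNc1nc(N)nc2ccc(OC)cc12` and compound 2 `CCCCNc1nc(N)nc2cc(OC)c(OC)cc12` share one core. In an ADME assay on HEK293 cells for agonist activity at Toll-like receptor 8 (Homo sapiens), read by a luciferase reporter, with a stated time of 6 h (on this read-out higher numbers stand for an effect only at larger amounts of compound and lower numbers for an effect already at smaller amounts), compound 1 gives 1.8 uM, and compound 2 gives 1.1 uM. The change between them, (methoxy in place of hydrogen on an aromatic carbon), produced a 1.6-fold lower number from compound 1 to compound 2 (0.21 log units; within the scatter). Compound 3 `CCCCNc1nc(N)nc2cccc(C(=O)N[C@@H](C)c3ccccc3)c12` carries a different core; how its core differs from that of compound 1 is not broken down here. In this assay compound 3 reaches only a limit of the assay, > 25 uM, a limit noted as the limit of > 25 uM in this assay, at which 1 of the 3 values shown sits. Compound 4 `CCCCNc1nc(N)nc2cccc(C(=O)N[C@@H](C)c3cccc(OC)c3)c12` is to be measured in this assay; it differs from compound 3 by methoxy in place of hydrogen on an aromatic carbon, the same kind of change as from compound 1 to compound 2, though here the aromatic carbon sits meta to a large group rather than in a fused system ortho to a methoxy group. Since that earlier change stayed within the scatter, a step that the limit leaves unreadable from compound 3 to compound 4 is the step expected, and compound 4 is estimated at 30 uM, between 10 uM and 100 uM.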

Compound 4, minimum effective concentration: > 25 uM
Compound 4 ended at the assay's limit (the forecaster's own chance of this, stated with the estimate: 70%); the middle value does not contradict the limit.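

Compound 3 and compound 4 both end at a limit of this assay, so no step between them can be read: the limit of > 25 uM in this assay, at which 2 of the 4 values shown sit.

The compounds shown leave open whether changing phenyl to 3-methoxyphenyl alters the minimum effective concentration at all.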